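Hydroxy to Methoxy in a Growth-Inhibition Series

The source may report more compounds than this note shows. Statements on the series, on what has been measured and on what is new or still open speak of the compounds shown alone.

In a functional assay on NCI-H522 cells (Homo sapiens) for antiproliferative activity, read by sulforhodamine B assay, with a stated time of 48 h (on this read-out higher numbers stand for weaker inhibition of growth and lower numbers for stronger inhibition of growth), compound 1 (`O=C(NCCCNc1cc(-c2cn(-c3ccccc3)nc2-c2cccc(O)c2)ccn1)Nc1ccc(F)cc1`) gives 9490 nM, and compound 2 (`O=C(NCCCNc1cc(-c2cn(-c3ccccc3)nc2-c2cccc(O)c2)ccn1)Nc1cccc(C(F)(F)F)c1`) gives 11000 nM, so these two stand level within the scatter. Compound 3 (`COc1cccc(-c2nn(-c3ccccc3)cc2-c2ccnc(NCCCNC(=O)Nc3ccc(F)cc3)c2)c1`) differs from compound 1 by methyl in place of hydrogen on an oxygen on an aromatic ring, which turns 3-hydroxyphenyl into 3-methoxyphenyl. Going by the values given here, the only measured step, a 1.2-fold higher number from compound 1 to compound 2 (0.06 log units; within the scatter), concerns an amide-type nitrogen rather than this oxygen, so it offers little guidance, and no change at this oxygen has been measured. The expected result is a 1.3-fold higher number from compound 1 to compound 3 (0.10 log units; within the scatter), with no shift beyond the scatter anticipated. For compound 3 the estimated value is 12000 nM, with an expected range of 5000 nM to 30000 nM.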

Compound 3, concentration for total growth inhibition: 12000 nM
Estimate against measurement, compound 3: no gap at the digits printed, within the range that was stated.
By their numbers in this assay, from the lowest: compounds 1, 2 and 3 (each within the scatter of the next).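

The first change measured at this oxygen, methyl in place of hydrogen, stays within the scatter in this assay (a 1.3-fold higher number from compound 1 to compound 3 (0.10 log units; within the scatter)). In this one pair, the hydrogen on the oxygen is therefore not needed to keep the reading where it stands. No outside evidence bears on this result. Going by these compounds, whether an ethyl or benzyl group on this oxygen, or an amine in place of the hydroxy, would shift the number stays open. So does whether the same change would behave alike with the 3-(trifluoromethyl)phenyl group of compound 2.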